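Removing the Methyl From the Methoxy Group

The source may hold more compounds than are shown below. What is called first, only, known or untested is meant among the compounds shown, and "the series" means these compounds.

Compound 1, `COc1cc(-c2nn(-c3cccc(NC(=O)c4cccc(C(F)(F)F)c4)c3)cc2-c2ccncc2)ccc1Cl`: in a functional assay on SF-268 cells (Homo sapiens) for inhibition, read by sulforhodamine B assay, with a stated time of 48 h (on this read-out higher numbers stand for weaker inhibition of growth and lower numbers for stronger inhibition of growth), compound 1 gives > 50000 nM, a limit of the assay.
Compound 2, `COc1cc(-c2nn(-c3cccc(NC(=O)Nc4ccc(Cl)c(C(F)(F)F)c4)c3)cc2-c2ccncc2)ccc1Cl`: in this assay compound 2 gives 9140 nM.

Compound 2 holds the only number shown; the other value is a limit, as the limit of > 50000 nM in this assay, at which 1 of the 2 values shown sits, records. The step of an at least 5.4-fold lower number from compound 1 to compound 2 (0.73 log units; beyond the scatter) came from putting (4-chloro-3-(trifluoromethyl)phenyl)amino in place of 3-(trifluoromethyl)phenyl on a carbonyl carbon.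

Compound 3, `O=C(Nc1cccc(-n2cc(-c3ccncc3)c(-c3ccc(Cl)c(O)c3)n2)c1)Nc1ccc(Cl)c(C(F)(F)F)c1`, keeps that urea and changes a different part of compound 2: hydrogen in place of methyl on an oxygen on an aromatic ring, methoxy to hydroxy. Among the measured compounds shown here, no measured step touches this oxygen, so the single known step does not bear on it. The expected step of a 1.0-fold lower number from compound 2 to compound 3 (0.01 log units; within the scatter) is therefore none beyond the scatter. Compound 3 is estimated to give 9000 nM in this assay, within 3000 nM to 30000 nM.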

Compound 3, concentration for total growth inhibition: 6980 nM
The estimate for compound 3 lay 1.3-fold (0.11 log units) above the measured number; the range from low to high includes it.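

In this assay, the methyl on this oxygen can be replaced by hydrogen with a 1.3-fold lower number from compound 2 to compound 3 (0.12 log units; within the scatter) as the result, so methoxy and hydroxy cannot be told apart on this read-out. Among the compounds shown here, this is the first measured step at the 4-chloro-3-methoxyphenyl group: the earlier step, at the other end of the molecule, lay beyond the scatter, whereas this one lies within it. Nothing measured here speaks to what lies behind this result.

The compounds shown carry only methoxy and hydroxy at this place, so it remains open whether the oxygen itself matters, which an amine or a longer chain such as ethoxy there would begin to test. One pair also cannot tell whether the same would hold with the amide of compound 1 in place of the urea.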